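The compounds below may be only part of what the source reports. "The series", "measured", "known", "first", "only" and "open" are said of these compounds alone.

Working notes on the series.

Compound 1 `COc1ccc(N)c(C2=NN(C(=O)c3ccccc3)CC2)c1` in an assay on isolated protein for inhibition of Nitric oxide synthase, inducible (Homo sapiens), with a stated time of 30 min, tested at 1 mM (a lower number here means less inhibition, a higher number more inhibition at the concentration tested (going by the name of the read-out)), gives 12.2%. Compound 2 `COc1ccc(N)c(C2=NN(C(=O)CCc3ccccc3)CC2)c1` differs by phenethyl in place of phenyl on a carbonyl carbon and in this assay compound 2 gives 21.2%, a step of a number 9 percentage points higher from compound 1 to compound 2 (within the scatter). Compound 3 `COc1cc(N)c(C2=NN(C(=O)c3ccccc3)CC2)cc1OC` differs from compound 1 by methoxy in place of hydrogen on an aromatic carbon, and in this assay compound 3 gives 28.9%, a step of a number 16.7 percentage points higher from compound 1 to compound 3 (beyond the scatter). Compound 4 `COc1cc(N)c(C2=NN(C(=O)CCc3ccccc3)CC2)cc1OC` is not yet measured; it differs from compound 3 by phenethyl in place of phenyl on a carbonyl carbon, the same change as from compound 1 to compound 2, on a core that differs from that of compound 1 by methoxy in place of hydrogen on an aromatic carbon. Resting on the earlier step of a number 9 percentage points higher from compound 1 to compound 2 (within the scatter), the expected step for compound 4 is a number 8.1 percentage points higher from compound 3 to compound 4 (within the scatter). Compound 4 is therefore estimated at 37% in this assay, between 22% and 52%.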

Compound 4, a percentage reported as inhibition, at one concentration (the size of the read-out at that concentration, not a potency): 23.7%
Estimate against measurement, compound 4: 13.3 percentage points above; measured number inside the range.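

In this assay, phenethyl in place of phenyl on a carbonyl carbon does not carry over unchanged from the core of compound 1 to the core of compound 3, where the step is a number 5.2 percentage points lower from compound 3 to compound 4 (within the scatter): the same change on two cores in this assay, a number 9 percentage points higher (within the scatter) from compound 1 to compound 2 and a number 5.2 percentage points lower (within the scatter) from compound 3 to compound 4, 14.2 percentage points apart, beyond the scatter of two such steps. Methoxy in place of hydrogen on an aromatic carbon gives a number 2.5 percentage points higher from compound 2 to compound 4 (within the scatter), so it too depends on its partner group: the same change on two cores in this assay, a number 16.7 percentage points higher (beyond the scatter) from compound 1 to compound 3 and a number 2.5 percentage points higher (within the scatter) from compound 2 to compound 4, 14.2 percentage points apart, beyond the scatter of two such steps. This shows that the two changes do not simply add across these four compounds, but it does not show why, nor whether the same holds on any other core.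

Still open, going by these compounds, is how a longer chain than phenethyl, or a carboxylic acid on that carbonyl carbon, would read on either core. Readings at a single concentration also leave the potency of all four compounds open.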